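Swapping the Aryl Group on the Sulfonamide

This account rests on a few compounds, and the source may have more. Where it says the series, first, only, none or still open, it means among the compounds named here.

Compound 2 `O=C(/C=C/c1cccc(NS(=O)(=O)c2cc(Cl)cc(Cl)c2)c1)c1nc2ccccc2[nH]1` is one of two measured analogues built on a shared core. In a functional assay on 143B cells (Homo sapiens) for antiproliferative activity, read by MTT assay, with a stated time of 48 h (on this read-out lower numbers stand for stronger inhibition and higher numbers for weaker inhibition), compound 2 gives 5950 nM, and compound 1 `Cc1ccccc1S(=O)(=O)Nc1cccc(/C=C/C(=O)c2nc3ccccc3[nH]2)c1` gives 4060 nM, the two sitting close together. Compound 3 `Cc1ccc(S(=O)(=O)Nc2cccc(/C=C/C(=O)c3nc4ccccc4[nH]3)c2)cc1C` differs from compound 2 by 3,4-dimethylphenyl in place of 3,5-dichlorophenyl on a sulfonyl sulfur. For the measured compounds named here, the only measured step at the same position is a 1.5-fold higher number from compound 1 to compound 2 (0.17 log units; within the scatter), and it bears directly on this change. A further swap of one aryl group for another is therefore expected to move little, so the expected step is a 1.3-fold lower number from compound 2 to compound 3 (0.12 log units; within the scatter), not beyond the scatter. Compound 3 is estimated at 4500 nM, ranging from 1500 nM to 14000 nM.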

Compound 3, half-maximal inhibitory concentration: 5050 nM
The estimate for compound 3 lay 1.1-fold (0.05 log units) below the measured number, and the stated range covers the measured number.
By their numbers in this assay, from the lowest: compounds 1, 3 and 2 (each within the scatter of the next).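

In this assay, the new steps are a 1.2-fold lower number from compound 2 to compound 3 (0.07 log units; within the scatter) and a 1.2-fold higher number from compound 1 to compound 3 (0.09 log units; within the scatter). All three aryl groups on the sulfonyl sulfur now lie within the scatter of one another, even though 3,4-dimethylphenyl carries only carbon where 3,5-dichlorophenyl carries two chlorine atoms. No supporting data explain this lack of separation.

All three compounds keep a six-membered aromatic carbon ring at this position. From the compounds shown here alone, whether a butyl chain there, or a phenyl ring bearing an amine or a carboxylic acid, would stay within the scatter remains open.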